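Chloro for Methyl on a Sodium/Hydrogen Exchanger Inhibitor Core

The source may report more compounds than this note shows. Statements on the series, on what has been measured and on what is new or still open speak of the compounds shown alone.

Compound 1 `Cc1c(C(=O)N=C(N)N)cc(S(C)(=O)=O)c(Cl)c1C`: 58 nM
Compound 2 `Cc1c(C(=O)N=C(N)N)cc(S(C)(=O)=O)c(C)c1C`: 55 nM
Compound 3 `Cc1cc(-n2ccnc2)c(S(C)(=O)=O)cc1C(=O)N=C(N)N`: 23 nM

The three measured compounds were tested in a functional assay for inhibition of sodium/hydrogen exchanger (Oryctolagus cuniculus); a higher number here means a weaker inhibitor, a lower number a stronger inhibitor. Compound 1 gives 58 nM, compound 2 gives 55 nM, and compound 3 gives 23 nM, the lowest of the three. Compound 1 and compound 2 differ in one place: chloro in place of methyl on an aromatic carbon. That exchange made a 1.1-fold higher number from compound 2 to compound 1 (0.02 log units; within the scatter). The difference between the core of compound 2 and the core of compound 3 is not broken down here.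

Compound 4 `CS(=O)(=O)c1cc(C(=O)N=C(N)N)c(Cl)cc1-n1ccnc1` has not yet been measured. It differs from compound 3 by the same kind of change: chloro in place of methyl on an aromatic carbon. The surroundings differ, though: in compound 1 the chloro stands ortho to a methyl group and ortho to a methylsulfonyl group, meta to a methyl group and para to a group of 6 heavy atoms, whereas in compound 4 it stands ortho to a group of 6 heavy atoms, meta to a 1H-imidazol-1-yl group and para to a methylsulfonyl group. Because the earlier exchange gave a 1.1-fold higher number from compound 2 to compound 1 (0.02 log units; within the scatter), the step from compound 3 to compound 4 is expected to be about as small, a 1.1-fold higher number from compound 3 to compound 4 (0.04 log units; within the scatter). Compound 4 is therefore estimated at 25 nM, with a likely range from 12 nM to 50 nM.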

Compound 4, half-maximal inhibitory concentration: 130 nM
Compound 4: middle estimate off by 5.2-fold (0.72 log units), on the low side, and the stated range ends below it.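

In this assay, chloro in place of methyl on an aromatic carbon made a clear difference on the core of compound 3 (a 5.7-fold higher number from compound 3 to compound 4 (0.75 log units; beyond the scatter)), whereas the same exchange made no difference beyond the scatter on the core of compound 2. The size of this exchange therefore did not carry over from one core to the other: the same change on two cores in this assay, a 1.1-fold higher number (0.02 log units; within the scatter) from compound 2 to compound 1 and a 5.7-fold higher number (0.75 log units; beyond the scatter) from compound 3 to compound 4, 5.4-fold (0.73 log units) apart, beyond the scatter of two such steps. This shows that a near-silent exchange on one core in this series cannot be assumed to stay silent on another, but it does not show why, since two pairs of compounds cannot tell which difference between the cores matters or how the exchange would behave on a third core.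

The compounds shown leave open whether the weaker result belongs to chloro specifically or would come with other replacements for that methyl. A bare hydrogen, a methoxy group or an amine in that place on the core of compound 3 would help to separate these possibilities.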